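A few compounds are considered here, and "the series" means these few. Any claim that something is new, unique, unknown or untested is made for them only; others in the source may bear on it.

Compound 1, `COc1cc(-c2nn(-c3cccc(NC(=O)Nc4ccc(Cl)c(Cl)c4)c3)cc2-c2ccncc2)ccc1Cl`: in a functional assay on OVCAR-3 cells (Homo sapiens) for inhibition, read by sulforhodamine B assay, with a stated time of 48 h (on this read-out higher numbers stand for lower toxicity in this test and lower numbers for higher toxicity in this test), compound 1 gives > 50000 nM, which is a limit of the assay and not a number.
Compound 2, `COc1cc(-c2nn(-c3cccc(NC(=O)Nc4cccc(C(F)(F)F)c4)c3)cc2-c2ccncc2)ccc1Cl`: in this assay compound 2 gives 24700 nM.
Compound 3, `COc1cc(-c2nn(-c3cccc(NC(=O)Nc4ccc(Cl)c(C(F)(F)F)c4)c3)cc2-c2ccncc2)ccc1Cl`: in this assay compound 3 gives > 32500 nM, again only a limit.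

Compound 3 thus stands at a limit of the assay. Compound 1 also stands at a limit, and compound 2 alone gives a number, so none of the three is clearly set apart from the others. Compound 4, `COc1cc(-c2nn(-c3cccc(NC(=O)c4ccccc4)c3)cc2-c2ccncc2)ccc1Cl`, differs from compound 3 by phenyl in place of (4-chloro-3-(trifluoromethyl)phenyl)amino on a carbonyl carbon. Going by the values given here, no measured step touches that carbonyl carbon. The steps that exist, an at least 2.0-fold lower number from compound 1 to compound 2 (0.30 log units; that floor lies within the scatter) and an at least 1.3-fold higher number from compound 2 to compound 3 (0.11 log units; that floor lies within the scatter), both have floors within the scatter, and the step from compound 1 to compound 3 cannot be read from two limits. Nothing therefore points to a step beyond the scatter, and compound 4 is expected to stay near the same weak level, a step that the limit leaves unreadable from compound 3 to compound 4, estimated at 40000 nM within 15000 nM to 100000 nM.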

Compound 4, concentration lethal to 50% of the cells: 95800 nM
The estimate for compound 4 lay 2.4-fold (0.38 log units) below the measured number; the measured number falls inside the stated range.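

On this carbonyl carbon, phenyl in place of (3-(trifluoromethyl)phenyl)amino gives a 3.9-fold higher number from compound 2 to compound 4 (0.59 log units; beyond the scatter) in this assay, the first step in the series shown that clearly lies beyond the scatter. A higher number here means lower toxicity in this test, so this one pair shows that the change weakens the effect. The steps from compound 1 and from compound 3 to compound 4 cannot be read, as both of those compounds give only limits.

From the compounds shown here alone, the change removes the nitrogen and the trifluoromethyl together, so their separate shares stay open. Also open, going by these compounds, is how an alkyl amine or a longer carbon chain on this carbonyl carbon would read.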